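Amine-nitrogen substituents and mouse microsomal stability

The source may report more compounds than this note shows. Statements on the series, on what has been measured and on what is new or still open speak of the compounds shown alone.

Measured compounds:
compound 1 `CN(C[C@H]1Cc2ncccc2CN1)[C@H]1CCCc2cccnc21`: 53%
compound 2 `NC/C=C\CN(C[C@H]1Cc2ncccc2CN1)[C@H]1CCCc2cccnc21`: 37%
compound 3 `c1cnc2c(c1)CN[C@@H](CN(CCCCNC1CCOCC1)[C@H]1CCCc3cccnc31)C2`: 35%

In an ADME assay on microsomes from liver (Mus musculus) for metabolic stability, using NADPH, with a stated time of 10 min (a lower number here means that less of the compound is left, a higher number that more of the compound is left), compound 1 gives 53%, the highest of the three numbers measured, and both other compounds lie beyond the scatter below it. Replacing the hydrogen on the saturated chain carbon bound to the amine nitrogen with a 3-aminoprop-1-en-1-yl group gave a number 16 percentage points lower from compound 1 to compound 2 (beyond the scatter); replacing it with a 3-((oxan-4-yl)amino)propyl group gave a number 18 percentage points lower from compound 1 to compound 3 (beyond the scatter). Between those two substituents the difference was a number 2 percentage points lower from compound 2 to compound 3 (within the scatter), so the two replacements look alike in this assay.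

Compound 4 `c1cnc2c(c1)CN[C@@H](CN(CCCCNC1COC1)[C@H]1CCCc3cccnc31)C2` differs from compound 1 by a group of 8 heavy atoms (6 carbon, 1 nitrogen, 1 oxygen; one four-membered non-aromatic ring with 1 hetero atom) in place of a hydrogen atom, on a saturated chain carbon bound to an amine nitrogen. For the measured compounds named here, the change is closest in kind to the one leading to compound 3, and both measured replacements of that hydrogen lowered the remaining fraction by a modest amount. Compound 4 is therefore expected to give 35%, in the range 22% to 48%. This estimate corresponds to an expected step of a number 18 percentage points lower from compound 1 to compound 4 (beyond the scatter).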

Compound 4, percent of the compound remaining: 41%
For compound 4 the middle estimate is 6 percentage points below the measured one; low and high end bracket the measured number.
By their numbers in this assay, from the lowest: compounds 3, 2 and 4 (each within the scatter of the next); then compound 1.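

In this assay the oxetan-3-yl-bearing chain also stays beyond the scatter of the hydrogen of compound 1, with a number 12 percentage points lower from compound 1 to compound 4 (beyond the scatter) on that saturated chain carbon, so all three substituents measured at this place lie under compound 1. Oxetan-3-yl in place of oxan-4-yl on the amine nitrogen gives a number 6 percentage points higher from compound 3 to compound 4 (within the scatter) and the comparison with the 3-aminoprop-1-en-1-yl group gives a number 4 percentage points higher from compound 2 to compound 4 (within the scatter), which leaves compounds 2, 3 and 4 not separated from one another in this read-out. No measurement at hand explains these numbers.

On these data alone, it remains open whether a piperidin-4-yl on that amine nitrogen, or a carboxylic acid at the end of the chain, would differ from compounds 3 and 4. Also open, as far as these compounds go, is how a shorter or longer chain carrying the oxetan-3-yl amine would compare with compound 4.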